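Returning the 4-nitrophenyl group to the ring nitrogen

The source may report more compounds than this note shows. Statements on the series, on what has been measured and on what is new or still open speak of the compounds shown alone.

Of the compounds shown here, three on one shared core have been tested in a functional assay on the whole organism (strain Wistar) for inhibition, with Rattus norvegicus as the target, read by paw edema, with stated times of 30 min and 120 min, at a dose of 50 mg/kg by the oral route; on this read-out higher numbers stand for more inhibition at the one dose given (going by the name of the read-out) and lower numbers for less inhibition. Compound 1 `Cc1ccc(C2=NN(c3ccc([N+](=O)[O-])cc3)C(c3cn(-c4ccccc4)nc3-c3ccc(Cl)c(Cl)c3)C2)cc1` gives 71.9%, compound 2 `CCC(=O)N1N=C(c2ccc(C)cc2)CC1c1cn(-c2ccccc2)nc1-c1ccc(Cl)c(Cl)c1` gives 70.3%, and compound 3 `CCC(=O)N1N=C(c2ccc(F)cc2)CC1c1cn(-c2ccccc2)nc1-c1ccc(Cl)c(Cl)c1` gives 75.6%. Compound 3 stands at the upper end of these three numbers, yet its gaps to compound 1 and to compound 2 both lie within the scatter. Compound 4 `O=[N+]([O-])c1ccc(N2N=C(c3ccc(F)cc3)CC2c2cn(-c3ccccc3)nc2-c2ccc(Cl)c(Cl)c2)cc1` has not been measured; it differs from compound 3 by 4-nitrophenyl in place of propanoyl on an amine nitrogen in a ring. The step that bears on this is a number 1.6 percentage points lower from compound 1 to compound 2 (within the scatter), the same exchange run in the opposite direction, whereas a number 5.3 percentage points higher from compound 2 to compound 3 (within the scatter) concerns a different place. Compound 4 is therefore expected to show a number 1.4 percentage points higher from compound 3 to compound 4 (within the scatter), nothing beyond the scatter. The estimated value of compound 4 is 77%, with a range from 66% to 86%.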

Compound 4, a percentage reported as inhibition, in the whole organism at one dose (the size of the read-out at that dose, not a potency): 65.6%
The estimate for compound 4 lay 11.4 percentage points above the measured number, outside the stated range (below it).
By their numbers in this assay, from the lowest: compounds 4, 2, 1 and 3 (each within the scatter of the next).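

In this assay, the exchange at the amine nitrogen in a ring now has a reading on the fluoro-bearing core, a number 10 percentage points lower from compound 3 to compound 4 (within the scatter), and the fluoro for methyl exchange has one with 4-nitrophenyl in place, a number 6.3 percentage points lower from compound 1 to compound 4 (within the scatter). The exchange at this position points in opposite directions on the two cores, yet the two steps still agree within the scatter: the same change on two cores in this assay, a number 1.6 percentage points lower (within the scatter) from compound 1 to compound 2 and a number 10 percentage points higher (within the scatter) from compound 4 to compound 3, 11.6 percentage points apart, within the scatter of two such steps The fluoro for methyl exchange likewise shows no firm dependence on the group at the nitrogen: the same change on two cores in this assay, a number 5.3 percentage points higher (within the scatter) from compound 2 to compound 3 and a number 6.3 percentage points lower (within the scatter) from compound 1 to compound 4, 11.6 percentage points apart, within the scatter of two such steps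

The compounds shown leave open how an acetyl group, or a phenyl ring carrying a carboxylic acid, would read on this nitrogen.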